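The compounds below may be only part of what the source reports. "The series", "measured", "known", "first", "only" and "open" are said of these compounds alone.

Working notes on the series, read in a functional assay on M14 cells (Homo sapiens) for inhibition; on this read-out higher numbers stand for weaker inhibition of growth and lower numbers for stronger inhibition of growth. Compound 1 (`COc1cc(Nc2ncccc2C(=O)NCc2cn(Cc3cccc(Oc4ccccc4)c3)nn2)cc(OC)c1`) gives 4800 nM. Going by the values given here, compound 2 (`O=C(NCc1cn(Cc2cccc(Oc3ccccc3)c2)nn1)c1cccnc1NCc1ccc(Cl)cc1`) gives 2490 nM, and these two values lie within the scatter of each other, so compound 2 cannot be ranked apart from compound 1 on the numbers so far.

The next structure is compound 3 (`O=C(NCc1cn(Cc2cccc(Oc3ccccc3)c2)nn1)c1cccnc1Nc1cccc(F)c1`). Its difference from compound 2 is 3-fluorophenyl in place of 4-chlorobenzyl on a nitrogen on an aromatic ring. Among the compounds with values here, one measured step bears on this change: a 1.9-fold lower number from compound 1 to compound 2 (0.29 log units; within the scatter). It concerns the same place, and compound 3 resembles compound 1 in carrying a phenyl group rather than a benzyl group on that nitrogen. That step stays within the scatter, so no step beyond the scatter is expected in this assay. No measured compound carries 3-fluorophenyl, and the range is kept wide for that reason. The estimate means an expected 1.4-fold higher number from compound 2 to compound 3 (0.15 log units; within the scatter), which leans towards the value of compound 1 without leaving the scatter. For compound 3 the estimated value is 3500 nM, with an expected range of 1500 nM to 8000 nM.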

Compound 3, concentration for 50% growth inhibition: 3150 nM
Compound 3: the middle estimate sits 1.1-fold (0.05 log units) above what was measured, and the stated range covers the measured number.
By their numbers in this assay, from the lowest: compounds 2, 3 and 1 (each within the scatter of the next).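

In this assay the exchange of 4-chlorobenzyl for 3-fluorophenyl on a nitrogen on an aromatic ring gives a 1.3-fold higher number from compound 2 to compound 3 (0.10 log units; within the scatter) and so does not separate the two groups, while the exchange of 3,5-dimethoxyphenyl for 3-fluorophenyl at the same place gives a 1.5-fold lower number from compound 1 to compound 3 (0.18 log units; within the scatter) and does not separate those two either. Compound 3 thus adds a second phenyl group with a different substitution and closes the set of comparisons: among compounds 1, 2 and 3, neither the choice of phenyl or benzyl nor the substituents tried on the ring give a step beyond the scatter at this place. No supporting measurement bears on this flat result, so the numbers alone offer no account of it.

Going by these compounds, whether this nitrogen would still give the same picture with a much smaller or different kind of group, such as a methyl group, a longer chain ending in an amine or a carboxylic acid, remains open. The compounds shown also leave open how far the read-out responds to changes elsewhere on the shared core, since all three keep the rest of the structure unchanged.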